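Toward compound 4: the chain end replaces the lactone

This account rests on a few compounds, and the source may have more. Where it says the series, first, only, none or still open, it means among the compounds named here.

Compound 1 `COC1=C[C@H](O)[C@H](C/C=C(\C)CC/C=C(\C)C[C@@H]2C[C@@H](C)C(=O)O2)[C@@H](C)C1=O`: > 30000 nM
Compound 2 `COC1=C(OC)[C@H](O)[C@H](C/C=C(\C)CC/C=C(\C)C[C@@H]2C[C@@H](C)C(=O)O2)[C@@H](C)C1=O`: 14100 nM
Compound 3 `COC1=C(OC)[C@H](OC(C)=O)[C@H](C/C=C(\C)CC/C=C(\C)C[C@@H]2C[C@@H](C)C(=O)O2)[C@@H](C)C1=O`: 11300 nM

In a functional assay on A549 cells (Homo sapiens) for inhibition, read by sulforhodamine B assay, with a stated time of 48 h (on this read-out lower numbers stand for stronger inhibition of growth and higher numbers for weaker inhibition of growth), compound 1 gives > 30000 nM, which is a limit of the assay rather than a number (the limit of > 30000 nM in this assay, at which 1 of the 3 values shown sits). In this assay compound 2 gives 14100 nM and compound 3 gives 11300 nM; these two numbers lie within the scatter of each other, so compound 2 stands together with compound 3 among the measured values. Two steps are known: an at least 2.1-fold lower number from compound 1 to compound 2 (0.32 log units; beyond the scatter) and a 1.2-fold lower number from compound 2 to compound 3 (0.10 log units; within the scatter). Both concern the shared core, not the chain. Compound 4 `COC1=C(OC)[C@H](O)[C@H](C/C=C(\C)CC/C=C(\C)CC/C=C(\C)CO)[C@@H](C)C1=O` differs from compound 2 on a saturated chain carbon bound to a double-bonded chain carbon: a group of 6 heavy atoms (5 carbon, 1 oxygen; no ring) in place of a group of 7 heavy atoms (5 carbon, 2 oxygen; one five-membered non-aromatic ring with 1 hetero atom), on a saturated chain carbon bound to a double-bonded chain carbon. Going by the values given here, no measured step covers such a change, so no step beyond the scatter is expected in either direction. Compound 4 is estimated at 15000 nM, with a range from 5000 nM to 45000 nM. That estimate means an expected 1.1-fold higher number from compound 2 to compound 4 (0.03 log units; within the scatter).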

Compound 4, concentration for 50% growth inhibition: 8200 nM
Estimate against measurement, compound 4: 1.8-fold (0.26 log units) above; measured number inside the range.
By their numbers in this assay, from the lowest: compounds 4, 3 and 2 (each within the scatter of the next). At a limit, above all of these: compound 1.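

In this assay, the chain end was exchanged on a saturated chain carbon bound to a double-bonded chain carbon, with 3-(hydroxymethyl)but-2-en-1-yl replacing the lactone group, and the step is a 1.7-fold lower number from compound 2 to compound 4 (0.24 log units; within the scatter). Unlike the earlier steps on the shared core, this shows that for this pair the lactone ring can be replaced without a change beyond the scatter. Nothing shown gives a reason for this outcome.

From the compounds shown here alone, it remains open whether an amine, a carboxylic acid or a longer chain at this position would move the number beyond the scatter. Going by these compounds, it is also open whether the same exchange would hold on the core of compound 1 or compound 3.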